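A few compounds are considered here, and "the series" means these few. Any claim that something is new, unique, unknown or untested is made for them only; others in the source may bear on it.

Of the compounds shown here, three have so far been measured in a functional assay on SGC-7901 cells (Homo sapiens) for inhibition, read by MTT assay, with a stated time of 48 h; on this read-out higher numbers stand for weaker inhibition and lower numbers for stronger inhibition.

Compound 1, `Cc1ccc(Oc2c(/C=N/OCc3snnc3C)c(C)nn2C)cc1`, gives 12800 nM.
Compound 2, `CCc1nnsc1CO/N=C/c1c(C)nn(C)c1Oc1ccc(C)cc1`, gives 19800 nM.
Compound 3, `CCc1nnsc1CO/N=C/c1c(C)nn(C)c1Cl`, gives only a limit of the assay, > 50000 nM.

Compound 1 and compound 2 share a core and differ in one place: methyl in place of hydrogen on a saturated chain carbon bound to an aromatic carbon. With this change the number moves by a 1.5-fold higher number from compound 1 to compound 2 (0.19 log units; within the scatter). Compound 2 and compound 3 differ by a chloro in place of 4-methylphenoxy on an aromatic carbon, and the number moves by an at least 2.5-fold higher number from compound 2 to compound 3 (0.40 log units; beyond the scatter); compound 3 sits at the limit of > 50000 nM in this assay, at which 1 of the 3 values shown sits. The difference between the core of compound 1 and the core of compound 3 is not broken down here.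

Compound 4, `CCCc1nnsc1CO/N=C/c1c(C)nn(C)c1Cl`, is not yet measured. It differs from compound 3 by methyl in place of hydrogen on a saturated chain carbon, two bonds along the chain from an aromatic carbon. This is the same kind of change as that from compound 1 to compound 2, though the place differs: there the methyl entered on a saturated chain carbon bound to an aromatic carbon, here on a saturated chain carbon, two bonds along the chain from an aromatic carbon. As the earlier step of a 1.5-fold higher number from compound 1 to compound 2 (0.19 log units; within the scatter) stayed within the scatter, a step of similar size is expected for compound 4, a step that the limit leaves unreadable from compound 3 to compound 4. Compound 3 reaches only the limit > 50000 nM in this assay. Compound 4 is therefore expected to be weak as well, near 70000 nM, and most likely again reported only as a limit.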

Compound 4, half-maximal inhibitory concentration: > 50000 nM
Compound 4: a limit, no number; the forecaster's own chance of this, stated with the estimate: 75%; the middle value is on the limit's open side.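

No step from compound 3 to compound 4 can be read in this assay, because both compounds stop at a limit of the assay rather than a number: the limit of > 50000 nM in this assay, at which 2 of the 4 values shown sit.

The compounds shown leave open where the true values of compound 3 and compound 4 lie, and whether going from ethyl to propyl changes the read-out at all.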